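A Side-Chain Exchange and Its Expected Effect on Activity

A few compounds are considered here, and "the series" means these few. Any claim that something is new, unique, unknown or untested is made for them only; others in the source may bear on it.

Of the compounds shown here, two built on one shared core have been measured in a functional assay on the whole organism (Tail, strain ICR) with Mus musculus as the target, in the tail flick test, with a stated time of 60 min, at a dose of 25 umol/kg by the oral route; on this read-out lower numbers stand for a weaker effect and higher numbers for a stronger effect at the one dose given. Compound 1, `C[C@@H](O)[C@H](NC(=O)CN(c1nc(Cl)nc2[nH]cnc12)C1CC1)C(=O)OCc1ccccc1`, gives 29.7% in this assay. Compound 2, `NC(=O)C[C@H](NC(=O)CN(c1nc(Cl)nc2[nH]cnc12)C1CC1)C(=O)O`, gives 43.1% in this assay, which places it at the top of the two numbers: its nearest neighbour is compound 1, and the gap between them lies beyond the scatter.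

Compound 3, `C[C@@H](O)[C@H](NC(=O)CN(c1nc(Cl)nc2[nH]cnc12)C1CC1)C(=O)O`, has not yet been measured. Relative to compound 2 it carries 1-hydroxyethyl in place of carbamoylmethyl on a saturated chain carbon bound to an amide-type nitrogen and a carbonyl carbon. Among the compounds with values here, no step between measured compounds of this kind has been recorded, so the size of the change is open. With only two measured points to lean on, and compound 2 at 43.1% as the starting value, the step from compound 2 to compound 3 in this assay is expected to be small, most likely downward but possibly not beyond the scatter, as a number 8.1 percentage points lower from compound 2 to compound 3 (within the scatter). Compound 3 is therefore estimated at 35%, with a range from 15% to 55% in this assay.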

Compound 3, a percentage reported as activity, at one dose (the size of the read-out at that dose, not a potency): 30.1%
Beside the measured number, compound 3's estimate is 4.9 percentage points above it; the measured number falls inside the stated range.
By their numbers in this assay, from the lowest: compounds 1 and 3 (each within the scatter of the next); then compound 2.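

In this assay the exchange on the saturated chain carbon bound to an amide-type nitrogen and a carbonyl carbon now has a size: 1-hydroxyethyl in place of carbamoylmethyl gives a number 13 percentage points lower from compound 2 to compound 3 (beyond the scatter) at this position, although both groups count one hydrogen-bond donor and one hydrogen-bond acceptor and neither carries a net charge. The second change, hydrogen in place of benzyl on an oxygen next to a carbonyl group, gives a number 0.4 percentage points higher from compound 1 to compound 3 (within the scatter) in this assay, so with 1-hydroxyethyl on the chain, this exchange leaves no difference that can be told from the scatter. Nothing available explains why the side-chain exchange moves the number while the exchange on the oxygen does not.

The compounds shown leave open how an amine, a longer alkyl chain or a plain methyl group would stand on that chain carbon, so one step cannot show a trend there. They also leave open whether a benzyl group on the oxygen would be equally without visible effect with carbamoylmethyl on the chain, and how a methyl or ethyl group on that oxygen would compare.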